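Amino for hydrogen in two benzyl-chloride isomers

The source may report more compounds than this note shows. Statements on the series, on what has been measured and on what is new or still open speak of the compounds shown alone.

Compound 1 `ClCc1ccc(Cn2cnc3c(Cl)ncnc32)cc1` and compound 3 `ClCc1cccc(Cn2cnc3c(Cl)ncnc32)c1` carry the same atoms joined differently; the difference between the two cores is not broken down here. In a functional assay on Hs-578T cells (Homo sapiens) for cytotoxicity, read by sulforhodamine B assay, with a stated time of 48 h (a lower number here means that less compound is tolerated, a higher number that more compound is tolerated), compound 1 gives only a limit, > 100000 nM. In this assay compound 3 gives 81300 nM. Compound 2 `Nc1nc(Cl)c2ncn(Cc3ccc(CCl)cc3)c2n1` arises from compound 1 by amino in place of hydrogen on an aromatic carbon. In this assay compound 2 again gives only a limit, > 100000 nM. The step that the two limits leave unreadable from compound 1 to compound 2 is therefore of unknown size, because the limit of > 100000 nM in this assay, at which 2 of the 3 values shown sit, hides both ends. Compound 4 `Nc1nc(Cl)c2ncn(Cc3cccc(CCl)c3)c2n1` arises from compound 3 by the same change, (amino in place of hydrogen on an aromatic carbon). With no readable precedent, compound 4 is expected to sit close to compound 3, an estimated step of a 1.2-fold higher number from compound 3 to compound 4 (0.09 log units; within the scatter). The value of compound 4 is estimated at 100000 nM, within 40000 nM to 250000 nM.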

Compound 4, concentration lethal to 50% of the cells: > 100000 nM
Compound 4: no number, only a limit; the forecaster's own chance of this, stated with the estimate: 55%; the middle value lies on the limit itself.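

In this assay, amino in place of hydrogen on an aromatic carbon of the core of compound 3 gives an at least 1.2-fold higher number from compound 3 to compound 4 (0.08 log units; that floor lies within the scatter). Compound 4 gives > 100000 nM, which is a limit and not a number, so this step has a floor but no readable size. The same change on the core of compound 1 cannot be read, and no comparison of its size across the two cores is possible, because both ends of that step are hidden: the limit of > 100000 nM in this assay, at which 3 of the 4 values shown sit.

From the compounds shown here alone, the true size of the amino step on either core remains open. Also open, going by these compounds, is where an amine or a longer chain in place of the benzyl chloride would fall in this assay.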